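Methyl-for-hydrogen step in two lactone cores

This account rests on a few compounds, and the source may have more. Where it says the series, first, only, none or still open, it means among the compounds named here.

Measured compounds:
- compound 1, `CCC1(C)CCOC1=O`: > 500 mg/kg
- compound 2, `CC(C)C1(C)CCOC1=O`: > 500 mg/kg
- compound 3, `CCC1CCSC1=O`: 232 mg/kg

In a functional assay on the whole organism with Mus musculus as the target, in the maximal electroshock model (a higher number here means that more compound is needed for the effect, a lower number that less compound is needed), compound 1 gives > 500 mg/kg, which is a limit of the assay and not a number. Compound 2 likewise gives only a limit in this assay, > 500 mg/kg. Compound 3 is the only one of the three with a measured number, 232 mg/kg. The difference between the core of compound 1 and the core of compound 3 is not broken down here.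

From compound 1 to compound 2 the change is methyl in place of hydrogen on a saturated chain carbon bound to a saturated chain carbon and a saturated ring carbon. Its size, a step that the two limits leave unreadable from compound 1 to compound 2, cannot be read, since both ends rest at the limit of > 500 mg/kg in this assay, at which 2 of the 3 values shown sit.

Compound 4, `CC(C)C1CCSC1=O`, has not been measured in this assay. For the measured compounds named here, it differs from compound 3 by methyl in place of hydrogen on a saturated chain carbon bound to a saturated chain carbon and a saturated ring carbon, the same change as the one from compound 1 to compound 2. Going by the values given here, the only pair that shows this change gives no readable size, so the expectation for compound 4 can rest only on the measured number of compound 3, 232 mg/kg, with wide room for movement either way. The step from compound 3 to compound 4 is therefore estimated as a 1.1-fold higher number from compound 3 to compound 4 (0.05 log units; within the scatter). Compound 4 is expected to come out near 260 mg/kg, somewhere between 120 mg/kg and 520 mg/kg, with a real chance that the assay again reports only a limit.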

Compound 4, dose for half-maximal effect: > 500 mg/kg
Compound 4 ended at the assay's limit; the forecaster's own chance of this, stated with the estimate: 30%; middle value at least 1.9-fold (0.28 log units) away from the limit.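

On the core of compound 3, putting methyl in place of hydrogen turns ethyl into isopropyl and gives, in this assay, an at least 2.1-fold higher number from compound 3 to compound 4 (0.33 log units; beyond the scatter), so more compound is needed for the effect after this change. Compound 4 gives > 500 mg/kg, which is a limit of the assay and not a number. The step on the core of compound 1 cannot be read, so this single readable pair shows the direction of the change on one core only, gives only the smallest size the step can have, and does not show that the change behaves the same way on the other core, in a set where readable numbers are scarce: the limit of > 500 mg/kg in this assay, at which 3 of the 4 values shown sit.

Still open, from the compounds shown here alone, is whether a straight propyl chain in place of the ethyl on the core of compound 3 would also raise the number, or whether the rise is specific to the isopropyl group. Also open, going by these compounds, is whether a hydroxyl group or an amine on the core of compound 1 would give a measured number at all, which any real comparison of the two cores would need.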